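A few compounds are considered here, and "the series" means these few. Any claim that something is new, unique, unknown or untested is made for them only; others in the source may bear on it.

Compound 1 `c1ccc2c(c1)ccn2-c1nc(N2CCCCC2)nc2ccccc12`: 50 ug/mL
Compound 2 `Cn1cc(-c2nc(N3CCNCC3)nc3ccccc23)c2ccccc21`: 50 ug/mL
Compound 3 `c1ccc(N2CCN(c3nc(-n4ccc5ccccc54)c4ccccc4n3)CC2)cc1`: 50 ug/mL

Within the data shown here, in a functional assay on DU-145 cells (Homo sapiens) for antiproliferative activity, read by MTT assay (a higher number here means a weaker inhibitor, a lower number a stronger inhibitor), compound 3 gives 50 ug/mL, and that number is level with what compound 1 and compound 2 show at the digits reported; the nearest of the two is compound 1 and the furthest compound 2, but neither gap reaches beyond the scatter, so no compound among the three can be called more or less active than another. Among the measured compounds shown here, the three compounds differ from one another in more than one place, so their equal readings give no single step to lean on.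

Compound 4 `c1ccc(N2CCN(c3nc(-n4ccc5ccccc54)c4ccccc4n3)CC2)nc1` has not yet been measured in this assay. It differs from compound 3 in one place: pyridin-2-yl in place of phenyl on an amine nitrogen in a ring. Nothing among the three measured compounds shows a change in this assay, whatever the substituent, so the step from compound 3 to compound 4 is expected to be none beyond the scatter, in either direction, as no change at the digits printed from compound 3 to compound 4 (within the scatter). Compound 4 is therefore estimated at 50 ug/mL in this assay, with a range from 25 ug/mL to 100 ug/mL.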

Compound 4, half-maximal inhibitory concentration: 50 ug/mL
For compound 4 middle estimate and measured number coincide at the digits printed, and the stated range covers the measured number.
By their numbers in this assay, from the lowest: compounds 1, 2, 3 and 4 (each within the scatter of the next).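

In this assay, among these compounds, the exchange of phenyl for pyridin-2-yl on an amine nitrogen in a ring gives no change at the digits printed from compound 3 to compound 4 (within the scatter) and this is the first comparison in which only one place differs. The earlier compounds shown here shared a reading, but their several differences left no single change to examine. At this position, the entering ring has the same heavy-atom count as the leaving ring but adds a ring nitrogen and one hydrogen-bond acceptor, and that single exchange leaves the reading within the scatter.

The compounds shown leave open whether a benzyl group, an acetyl group or a pyridin-4-yl group on the same amine nitrogen would give a different reading. No supporting measurement is available to explain the unchanged result.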